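Three Measured Neighbours and One Still Unknown

A few compounds are considered here, and "the series" means these few. Any claim that something is new, unique, unknown or untested is made for them only; others in the source may bear on it.

Of the compounds shown here, three have been tested in a functional assay on MKN-45 cells (Homo sapiens) for cytotoxicity, read by MTT assay, with a stated time of 72 h; on this read-out lower numbers stand for stronger inhibition and higher numbers for weaker inhibition. Compound 1 `COc1ccc(/C=N/NC(=O)Nc2ccc(Oc3ccnc4cc(OCCCN5CCCCC5)c(OC)cc34)c(F)c2)cc1` gives 660 nM. Compound 2 `COc1cc2c(Oc3ccc(NC(=O)N/N=C/c4ccc(F)cc4Cl)cc3F)ccnc2cc1OCCCN1CCCCC1` gives 270 nM in this assay. Compound 3 `COc1ccc(/C=N/NC(=O)Nc2ccc(Oc3ccnc4cc(OCCCN5CCCCC5)c(OC)cc34)c(F)c2)c(OC)c1` gives 1990 nM in this assay, the highest of the three numbers and therefore the weakest inhibition seen so far. Its nearest neighbour is compound 1, with a 3.0-fold higher number from compound 1 to compound 3 (0.48 log units; beyond the scatter), and its furthest is compound 2, with a 7.4-fold higher number from compound 2 to compound 3 (0.87 log units; beyond the scatter).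

Compound 4 `C=CCc1cccc(/C=N/NC(=O)Nc2ccc(Oc3ccnc4cc(OCCCN5CCCCC5)c(OC)cc34)c(F)c2)c1OC` has not yet been measured. It differs from compound 3 in a single place: 3-allyl-2-methoxyphenyl in place of 2,4-dimethoxyphenyl on a carbon with a double bond to nitrogen. Going by the values given here, two measured steps bear on this change. The step of a 3.0-fold higher number from compound 1 to compound 3 (0.48 log units; beyond the scatter) shows that adding a second methoxy raised the number, so removing one, as happens here, would be expected to pull it back down. The step of a 2.4-fold lower number from compound 1 to compound 2 (0.39 log units; beyond the scatter) shows that swapping groups on the same carbon shifts the number by a modest amount in this assay. Among the compounds with values here, no measured compound carries an allyl group, so that part of the change is a blank. On balance a modest lowering of the number is expected, a 2.8-fold lower number from compound 3 to compound 4 (0.45 log units; beyond the scatter), landing compound 4 near compound 1.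

Compound 4 is therefore estimated at 700 nM in this assay, with a range from 250 nM to 2000 nM.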

Compound 4, half-maximal inhibitory concentration: 670 nM
Compound 4: the middle estimate sits 1.0-fold (0.02 log units) above what was measured, within the range that was stated.
By their numbers in this assay, from the lowest: compound 2; then compounds 1 and 4 (each within the scatter of the next); then compound 3.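

In this assay, the 3-allyl-2-methoxyphenyl group on the carbon with a double bond to nitrogen gives a 3.0-fold lower number from compound 3 to compound 4 (0.47 log units; beyond the scatter), so the high number of compound 3 does not follow from simply having two groups on this ring. Set against the single group of the 4-methoxyphenyl ring, this change gives a 1.0-fold higher number from compound 1 to compound 4 (0.01 log units; within the scatter), which means the two compounds cannot be told apart in this assay, while the 2-chloro-4-fluorophenyl ring keeps the lowest number, with a 2.5-fold higher number from compound 2 to compound 4 (0.39 log units; beyond the scatter). This position therefore accepts a ring bearing an allyl group, the first seen here, and the identity of the groups on the ring matters more in this small set than their number, with compound 3 and compound 2 marking the two ends.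

Nothing measured here explains why these rings give different numbers. Still open, going by these compounds, is whether the allyl group itself contributes anything, and what a saturated propyl chain, an amine or a carboxylic acid would do on this ring in its place.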